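This account rests on a few compounds, and the source may have more. Where it says the series, first, only, none or still open, it means among the compounds named here.

Compound 1 `O=C(/C(=C\c1ccc(O)c([N+](=O)[O-])c1)SCc1ccc(Br)cc1)c1ccc(O)cc1O` and compound 2 `O=C(/C(=C\c1ccc(OC(F)(F)F)cc1)Sc1ccc(Br)cc1)c1ccc(Br)cc1` have both been tested in a functional assay on DU-145 cells (Homo sapiens) for inhibition, read by trypan blue exclusion, with a stated time of 96 h; a higher number here means a weaker inhibitor of growth, a lower number a stronger inhibitor of growth. In this assay compound 1 gives > 100000 nM, which is a limit of the assay and not a number. In this assay compound 2 gives 10000 nM. For the measured compounds named here, compound 1 thus stands at the limit of > 100000 nM in this assay, at which 1 of the 2 values shown sits, so only compound 2 has a value on the scale, and no step between measured compounds that differ in one place is available; the account has to rest on the two values shown.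

Compound 3 `O=C(/C(=C\c1ccc(O)c([N+](=O)[O-])c1)SCc1ccc(Br)cc1)c1ccc(Cl)cc1Cl` has not yet been measured in this assay. It differs from compound 1 in a single place: 2,4-dichlorophenyl in place of 2,4-dihydroxyphenyl on a carbonyl carbon. What this change does to growth inhibition is not known from the compounds shown, but compound 1 at a limit leaves room for a move in the direction of stronger inhibition of growth. The step from compound 1 expected for compound 3 in this assay is an at least 2.5-fold lower number from compound 1 to compound 3 (0.39 log units; beyond the scatter), a moderate one toward stronger inhibition of growth. Compound 3 is estimated at 40000 nM in this assay, with a range from 8000 nM to 200000 nM.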

Compound 3, concentration for 50% growth inhibition: 10000 nM
For compound 3 the middle estimate is 4.0-fold (0.60 log units) above the measured one; the range from low to high includes it.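

In this assay, the replacement of 2,4-dihydroxyphenyl by 2,4-dichlorophenyl on a carbonyl carbon gives an at least 10-fold lower number from compound 1 to compound 3 (1.00 log units; beyond the scatter). For the compounds shown here, this is the first step that can be read at this position, and it shows that the group on the carbonyl carbon bears on growth inhibition even with the rest of the core of compound 1 left unchanged. The full size of the step cannot be read, because compound 1 gives a limit of the assay and not a number: the limit of > 100000 nM in this assay, at which 1 of the 3 values shown sits.

The compounds shown do not separate the loss of the two hydroxyl groups from the arrival of the two chlorine atoms, so it remains open whether a plain phenyl, a ring carrying a single chlorine atom, or a 2,4-dimethoxyphenyl group would also give a lower number than compound 1. From the compounds shown here alone, it is equally open whether this change would carry the same weight in another setting, or whether an amine or a carboxylic acid on the ring at this position would move growth inhibition in the same direction.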